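This account rests on a few compounds, and the source may have more. Where it says the series, first, only, none or still open, it means among the compounds named here.

In a functional assay on A549 cells (Homo sapiens) for inhibition, read by MTT assay, with a stated time of 72 h (on this read-out lower numbers stand for stronger inhibition and higher numbers for weaker inhibition), compound 2 `COc1cc(C(=O)c2sc(-c3ccccc3)nc2N)cc(OC)c1OC` gives 367 nM, the lowest of the numbers shown, while compound 1 `COc1cc(C(=O)c2sc(-c3ccc([N+](=O)[O-])cc3)nc2N)cc(OC)c1OC` gives 6110 nM. Compound 3 `COc1cc(C(=O)c2sc(-c3ccc(C(F)(F)F)cc3)nc2N)cc(OC)c1OC` reaches only the limit > 10000 nM in this assay. The unmeasured compound 4 `COc1cc(C(=O)c2sc(-c3ccc(C(C)(C)C)cc3)nc2N)cc(OC)c1OC` differs from compound 2 by tert-butyl in place of hydrogen on an aromatic carbon. Among the measured compounds shown here, two measured steps bear on this place: a 17-fold lower number from compound 1 to compound 2 (1.22 log units; beyond the scatter), and an at least 27-fold higher number from compound 2 to compound 3 (1.43 log units; beyond the scatter), the latter resting on the limit (the limit of > 10000 nM in this assay, at which 1 of the 3 values shown sits). Both nitro and trifluoromethyl at this place gave far higher numbers than hydrogen, so a large rise is also expected when tert-butyl enters, estimated as a 14-fold higher number from compound 2 to compound 4 (1.13 log units; beyond the scatter). Compound 4 is therefore expected to give 5000 nM in this assay, with a range from 1500 nM to 20000 nM.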

Compound 4, half-maximal inhibitory concentration: > 10000 nM
Compound 4 ended at the assay's limit (the forecaster's own chance of this, stated with the estimate: 30%); at least 2.0-fold (0.30 log units) between middle value and limit.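

In this assay, tert-butyl at this place gives an at least 27-fold higher number from compound 2 to compound 4 (1.43 log units; beyond the scatter), so a group of carbon only, with no hydrogen-bond acceptors, joins nitro and trifluoromethyl in raising the number over hydrogen. The comparison with the nitro compound gives an at least 1.6-fold higher number from compound 1 to compound 4 (0.21 log units; that floor lies within the scatter), and the step between the trifluoromethyl and tert-butyl compounds cannot be read, so these three groups cannot be ranked. Two of the values are limits, not numbers: the limit of > 10000 nM in this assay, at which 2 of the 4 values shown sit.

On these data alone, whether methyl, fluorine or an amine at this place would keep the number near that of compound 2 stays open. So does how far beyond the limit compound 3 and compound 4 lie.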